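Adding a Methoxy Group: Estimating Cytotoxicity of Compound 4

The compounds below may be only part of what the source reports. "The series", "measured", "known", "first", "only" and "open" are said of these compounds alone.

Of the compounds shown here, three have been tested in a functional assay on HSC-2 cells (Homo sapiens) for cytotoxicity; on this read-out higher numbers stand for lower toxicity in this test and lower numbers for higher toxicity in this test. Compound 1 `COc1cc(/C=C2\Cc3ccccc3/C(=C\c3ccc([N+](=O)[O-])cc3)C2=O)ccc1O` gives 1450 nM in this assay. Compound 2 `COc1ccc(/C=C2\CCC/C(=C\c3ccc([N+](=O)[O-])cc3)C2=O)cc1OC` gives 2300 nM, and compound 3 `O=C1/C(=C/c2ccc(O)cc2)Cc2ccccc2/C1=C\c1ccc([N+](=O)[O-])cc1` gives 5200 nM. Compound 3 and compound 1 differ in one place: methoxy in place of hydrogen on an aromatic carbon. That change produced a 3.6-fold lower number from compound 3 to compound 1 (0.55 log units; beyond the scatter). Compound 4 `COc1cc(/C=C2\CCC/C(=C\c3ccc([N+](=O)[O-])cc3)C2=O)cc(OC)c1OC` is not yet measured; it differs from compound 2 by the same kind of change, (methoxy in place of hydrogen on an aromatic carbon), though here the entering group sits ortho to a methoxy group and meta to a methoxy group rather than ortho to a hydroxy group. The difference between the core of compound 2 and the core of compound 3 is not broken down here. A somewhat smaller step of a 1.8-fold lower number from compound 2 to compound 4 (0.25 log units; within the scatter) is expected, because a 3.6-fold lower number from compound 3 to compound 1 (0.55 log units; beyond the scatter) shows this kind of change moving toward lower numbers on a different core. Compound 4 is therefore estimated at 1300 nM, most likely between 600 nM and 3000 nM.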

Compound 4, half-maximal cytotoxic concentration: 760 nM
For compound 4 the middle estimate is 1.7-fold (0.23 log units) above the measured one, within the range that was stated.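

Adding the methoxy group in this assay gave a 3.0-fold lower number from compound 2 to compound 4 (0.48 log units; beyond the scatter). Set beside the earlier step, the change carried over from one core to the other in both direction and size: the same change on two cores in this assay, a 3.6-fold lower number (0.55 log units; beyond the scatter) from compound 3 to compound 1 and a 3.0-fold lower number (0.48 log units; beyond the scatter) from compound 2 to compound 4, 1.2-fold (0.07 log units) apart, within the scatter of two such steps. Among these compounds, this rests on only two pairs, however, and it shows neither why the number falls nor that the step would hold on any further core, or with the entering group in other surroundings.

The compounds shown leave open whether an amine or an ethoxy group in the same place would move the number as methoxy does. How the two cores compare on their own also stays open: no pair shown differs in the core alone.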